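Methyl on the Oxygen: Compound 2 to Compound 3

A few compounds are considered here, and "the series" means these few. Any claim that something is new, unique, unknown or untested is made for them only; others in the source may bear on it.

Compound 2 `CC1CC/C(=N\Nc2ccccc2O)c2ncc(C(=O)O)c(=O)n21` and compound 1 `CC1CC/C(=N\Nc2cccc(Cl)c2)c2ncc(C(=O)O)c(=O)n21` share one core and differ only in the group on the amine nitrogen. In a functional assay on the whole organism for inhibition, with Rattus norvegicus as the target (on this read-out higher numbers stand for an effect only at larger amounts of compound and lower numbers for an effect already at smaller amounts), compound 1 gives no number, only a limit of > 100 umol/kg. In this assay compound 2 likewise gives only a limit, > 100 umol/kg. The step that the two limits leave unreadable from compound 1 to compound 2 cannot be sized because both values sit at the limit of > 100 umol/kg in this assay, at which 2 of the 2 values shown sit. Compound 3 `COc1ccccc1N/N=C1\CCC(C)n2c1ncc(C(=O)O)c2=O` carries the change (methyl in place of hydrogen on an oxygen on an aromatic ring), hydroxy to methoxy. Among the measured compounds shown here, no measured step bears on so small a change, so the step that the limit leaves unreadable from compound 2 to compound 3 is expected to stay within the scatter. Compound 3 is thus estimated at 160 umol/kg, between 40 umol/kg and 650 umol/kg, most likely reported again as a limit.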

Compound 3, dose for 50% inhibition: > 1000 umol/kg
Compound 3: a limit, no number; the forecaster's own chance of this, stated with the estimate: 75%; at least 6.2-fold (0.79 log units) between middle value and limit.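

In this assay compound 3 gives only a limit, > 1000 umol/kg, so neither its step from compound 1 nor its step from compound 2 can be read. The compounds shown leave open whether any change to the group on the amine nitrogen yields an actual number.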